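Swapping the Aryl Group on Compound 1

A few compounds are considered here, and "the series" means these few. Any claim that something is new, unique, unknown or untested is made for them only; others in the source may bear on it.

Measured in a functional assay on MCF7 cells (Homo sapiens) for inhibition, read by MTT assay, with a stated time of 72 h; a lower number here means a stronger inhibitor, a higher number a weaker inhibitor:
Compound 1 `COc1cc(NC(C)CCCNC(=O)NNC(=O)Nc2ccc(Cl)cc2)c2ncccc2c1`: 180 nM
Compound 2 `COc1cc(NC(C)CCCNC(=O)Nc2cccc(C(F)(F)F)c2)c2ncccc2c1`: 3300 nM

Of these two, compound 1 has the lower number and is the stronger inhibitor, at 180 nM. The step followed here leads to compound 3 `COc1cc(NC(C)CCCNC(=O)NNC(=O)Nc2cccc(C(F)(F)F)c2)c2ncccc2c1`, which has not yet been measured. Its structural change is 3-(trifluoromethyl)phenyl in place of 4-chlorophenyl on an amide-type nitrogen.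

Among the measured compounds shown here, only one measured step bears on this change: an 18-fold higher number from compound 1 to compound 2 (1.26 log units; beyond the scatter). That step is large and beyond the scatter, but it exchanges the whole ((4-chlorophenyl)carbamoyl)amino group, not the 4-chlorophenyl group alone. Compound 3 keeps the carbamoyl amino portion that is lost in an 18-fold higher number from compound 1 to compound 2 (1.26 log units; beyond the scatter), so that step sets no direct measure for this change. For the measured compounds named here, no measured pair isolates the exchange of 4-chlorophenyl for 3-(trifluoromethyl)phenyl, so only a small step in this assay, toward a slightly higher number, is expected.

The expected change is a 1.4-fold higher number from compound 1 to compound 3 (0.14 log units; within the scatter).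

For compound 3 the estimated value is 250 nM, with an expected range from 70 nM to 900 nM.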

Compound 3, half-maximal inhibitory concentration: 190 nM
Compound 3: the middle estimate sits 1.3-fold (0.12 log units) above what was measured; measured number inside the range.
By their numbers in this assay, from the lowest: compounds 1 and 3 (each within the scatter of the next); then compound 2.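

In this assay, putting 3-(trifluoromethyl)phenyl in place of 4-chlorophenyl on the amide-type nitrogen gives a 1.1-fold higher number from compound 1 to compound 3 (0.02 log units; within the scatter), so this place takes a group of 10 heavy atoms instead of 7 with no step beyond the scatter. Compound 2 carries the same 3-(trifluoromethyl)phenyl and gives 3300 nM, whereas compound 3 gives 190 nM; the large step, an 18-fold higher number from compound 1 to compound 2 (1.26 log units; beyond the scatter), therefore cannot be laid on the aryl group and goes with the loss of the carbamoyl amino portion, which compound 3 keeps. Nothing at hand explains why these two aryl groups give such close values.

The two groups differ both in their substituent and in where it sits on the ring, so the compounds shown do not separate these two features of the change. On these data alone, it also remains open whether this tolerance extends to an unsubstituted phenyl, a pyridine ring or a phenyl bearing a carboxylic acid or an amine, and whether it would hold with a longer chain between the core and the carbonyl.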